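Hydrogen in place of methyl: the step to compound 4

The source may report more compounds than this note shows. Statements on the series, on what has been measured and on what is new or still open speak of the compounds shown alone.

Compound 1 (`Cc1ncccc1N1C[C@]2(CC[C@@H](CNc3cnn(-c4ccccc4F)c3)CC2)OC1=O`) offers no number to start from. In an ADME assay on brain (Rattus norvegicus) for protein binding (on this read-out higher numbers stand for a larger free fraction and lower numbers for a smaller free fraction), compound 1 is recorded as "not determined" (no result reported) and so has no place on the scale. Two related structures supply the only figures available. In this assay compound 2 (`Cc1ccccc1-c1ccc(NC[C@H]2CC[C@]3(CC2)CN(c2cccnn2)C(=O)O3)nn1`) gives 0.051 as its reading, and in the same this assay compound 3 (`O=C1O[C@]2(CC[C@H](CNc3ccc(-c4ncccc4F)cn3)CC2)CN1c1cccnn1`) gives 0.052 as its reading. These two values lie within the scatter of each other.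

Compound 4 (`O=C1O[C@]2(CC[C@H](CNc3cnn(-c4ccccc4F)c3)CC2)CN1c1cccnc1`) has yet to be measured. Its structure departs from that of compound 1 in one place (hydrogen in place of methyl on an aromatic carbon): hydrogen in place of methyl on an aromatic carbon, next to the ring nitrogen and ortho to a large group, so that 2-methylpyridin-3-yl becomes pyridin-3-yl. Among the compounds with values here, no measured step shows what this change does in this assay, and compound 1 cannot anchor it. The expectation is therefore of no shift beyond the scatter and no stated direction, with the level taken from compound 2 at 0.051 and compound 3 at 0.052 as the nearest guides. The estimate for compound 4 is 0.05 as its expected unbound fraction, with an expected range from 0.02 to 0.11 around it.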

Compound 4, unbound fraction: 0.025
Compound 4: middle estimate off by 2.0-fold (0.30 log units), on the high side; low and high end bracket the measured number.
By their numbers in this assay, from the lowest: compound 4; then compounds 2 and 3 (each within the scatter of the next).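

In this assay compound 1 stands as "not determined" (no result reported) while compound 4 gives 0.025, so the step between these two compounds cannot be read. The compounds shown leave open what replacing 2-methylpyridin-3-yl with pyridin-3-yl does to the unbound fraction. No available evidence bears on this result.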